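Cyano in place of hydroxy on compound 3

This account rests on a few compounds, and the source may have more. Where it says the series, first, only, none or still open, it means among the compounds named here.

Among the measured compounds shown here, in a physicochemical assay for lipophilicity, measured as octanol-water partition (a higher number here means a more lipophilic compound, a lower number a more polar compound), three compounds on a shared core have numbers so far. Compound 1 `O=C(NNc1ccnc2cc(Cl)ccc12)c1ccccc1/N=C/c1ccc(Cl)cc1Cl` gives 6.22 and compound 2 `COc1ccc(/C=N/c2ccccc2C(=O)NNc2ccnc3cc(Cl)ccc23)cc1OC` gives 4.97 while compound 3 `O=C(NNc1ccnc2cc(Cl)ccc12)c1ccccc1/N=C/c1ccc(O)cc1` gives 4.65 as the lowest of the three. Compound 4 `N#Cc1ccc(/C=N/c2ccccc2C(=O)NNc2ccnc3cc(Cl)ccc23)cc1` is still unmeasured. It has cyano in place of hydroxy on an aromatic carbon, para to a large group (cyano in place of hydroxy on an aromatic carbon), which turns 4-hydroxyphenyl into 4-cyanophenyl. Two measured steps at this same place bear on the change. For the measured compounds named here, the large one is a number 1.57 log units lower from compound 1 to compound 3 (beyond the scatter) and the modest one is a number 0.32 log units lower from compound 2 to compound 3 (beyond the scatter) but neither involves cyano, and no compound with cyano has a number yet. The modest step of a number 0.32 log units lower from compound 2 to compound 3 (beyond the scatter) is taken as the closer guide, and only a small upward move is expected from the low position of compound 3. The step expected is a number 0.20 log units higher from compound 3 to compound 4 (within the scatter) and a clear shift is not anticipated. The estimated value for compound 4 is 4.85 within an expected range of 4.3 to 5.4 on this measure.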

Compound 4, partition coefficient: 4.83
The estimate for compound 4 lay 0.02 log units above the measured number; low and high end bracket the measured number.
By their numbers in this assay, from the lowest: compounds 3, 4 and 2 (each within the scatter of the next, the first and the last beyond it); then compound 1.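

In this assay the step of a number 0.18 log units higher from compound 3 to compound 4 (within the scatter) shows that on an aromatic carbon para to a large group, hydroxy with its hydrogen-bond donor and cyano with none give numbers that cannot be told apart. The step of a number 0.14 log units lower from compound 2 to compound 4 (within the scatter) likewise leaves 4-cyanophenyl unresolved from 3,4-dimethoxyphenyl, even though compound 2 and compound 3 are separated beyond the scatter, while the step of a number 1.39 log units lower from compound 1 to compound 4 (beyond the scatter) shows that compound 1 stays apart from compound 4 as it does from compound 2 and compound 3. Nothing available accounts for these numbers.

The compounds shown leave open whether an amine or a carboxylic acid on this same carbon would also stay within the scatter of compound 3. They also leave open whether a single chloro group here would be enough to reach the number of compound 1.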